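Swapping one aryl group on the shared core

The source may report more compounds than this note shows. Statements on the series, on what has been measured and on what is new or still open speak of the compounds shown alone.

compound 1 (`O=C(NO)c1ccc(NCc2nc(-c3cccc(Cl)c3)nn2-c2ccccc2)cc1`) reads 5760 nM as a measured number
compound 2 (`COc1ccc(-n2nc(-c3ccc(O)cc3)nc2CNc2ccc(C(=O)NO)cc2)cc1`) reads > 20000 nM as a limit of the assay

Among the measured compounds shown here, in a functional assay on MGC-803 cells (Homo sapiens) for antiproliferative activity, read by MTT assay, with a stated time of 72 h (on this read-out higher numbers stand for weaker inhibition and lower numbers for stronger inhibition), compound 1 gives 5760 nM as the only true number so far. The other result, that of compound 2, is a limit of the assay. Compound 3 (`O=C(NO)c1ccc(NCc2nc(-c3ccc(F)cc3)nn2-c2ccccc2)cc1`) departs from compound 1 by one change (4-fluorophenyl in place of 3-chlorophenyl on an aromatic carbon), 4-fluorophenyl in place of 3-chlorophenyl on an aromatic carbon. For the measured compounds named here, no measured step bears on this change, so in this assay no shift beyond the usual scatter is expected, in either direction. The estimated 1.0-fold higher number from compound 1 to compound 3 (0.02 log units; within the scatter) is therefore small. For compound 3 the expected value is 6000 nM with an estimated range from 1800 nM to 20000 nM in this read-out.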

Compound 3, half-maximal inhibitory concentration: 8960 nM
Compound 3: middle estimate off by 1.5-fold (0.17 log units), on the low side; measured number inside the range.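

In this assay, the swap gives a 1.6-fold higher number from compound 1 to compound 3 (0.19 log units; within the scatter), so this position on the shared core takes 4-fluorophenyl in place of 3-chlorophenyl without a shift beyond the usual scatter. The change alters both the halogen and its place on the phenyl ring, and this single pair cannot separate the two. Nothing shown offers a cause for this step.

From the compounds shown here alone, whether an amine or a carboxylic acid on this phenyl ring would leave the number within the scatter remains open.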